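The source may hold more compounds than are shown below. What is called first, only, known or untested is meant among the compounds shown, and "the series" means these compounds.

Measured so far in a functional assay on MCF7 cells (Homo sapiens) for antiproliferative activity; a lower number here means a stronger inhibitor, a higher number a weaker inhibitor:
- compound 1, `CC(C)=CCc1cc(C(=O)Nc2cc3ccc(OCC4CCCNC4)c(C)c3oc2=O)ccc1O`: compound 1 gives 790 nM
- compound 2, `CC(C)=CCc1cc(C(=O)Nc2cc3ccc(OCCCN4CCCCC4)c(C)c3oc2=O)ccc1O`: for compound 2 only a limit is reached, > 50000 nM

Among the compounds with values here, compound 2 thus stands at the assay's limit, (the limit of > 50000 nM in this assay, at which 1 of the 2 values shown sits), and no number is known for it; the one measured step runs an at least 63-fold higher number from compound 1 to compound 2 (1.80 log units; beyond the scatter). The next compound, compound 3, `CC(C)=CCc1cc(C(=O)Nc2cc3ccc(OCCCNC(C)(C)c4ccccc4)c(C)c3oc2=O)ccc1O`, carries (1-methyl-1-phenylethyl)amino in place of piperidin-1-yl on a saturated chain carbon, three bonds along the chain from an oxygen on an aromatic ring. Within the data shown here, only that single step bears on this change, and it sits at the same end of the chain as the present one; it shows that a change there can move this assay by a large amount, but from a limit it gives no direction. A large step either way is therefore possible, and with compound 2 held at a limit only a move back toward a number could be resolved. For compound 3 the expected step is an at least 2.5-fold lower number from compound 2 to compound 3 (0.39 log units; beyond the scatter). Compound 3 is estimated at 20000 nM, between 2000 nM and 100000 nM.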

Compound 3, half-maximal inhibitory concentration: 1070 nM
Compound 3: the middle estimate sits 19-fold (1.27 log units) above what was measured, outside the stated range (below it).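

In this assay, the group at the end of this chain decides whether a number is reached at all: (1-methyl-1-phenylethyl)amino in place of piperidin-1-yl gives an at least 46-fold lower number from compound 2 to compound 3 (1.66 log units; beyond the scatter). The size of that step is only a bound, since compound 2 is held at a limit: the limit of > 50000 nM in this assay, at which 1 of the 3 values shown sits. The 2-((1-methyl-1-phenylethyl)amino)ethyl and piperidin-3-yl side chains stand level, with a 1.4-fold higher number from compound 1 to compound 3 (0.13 log units; within the scatter), so the loss seen with compound 2 does not extend to every amine-bearing group on the chain.

The amine hydrogen and the phenyl ring enter together, so the compounds shown do not tell which of them carries the step. An isopropylamino group, which keeps the amine hydrogen without the phenyl ring, or a benzyl(methyl)amino group, which keeps a phenyl ring without that hydrogen, would separate the two.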